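A few compounds are considered here, and "the series" means these few. Any claim that something is new, unique, unknown or untested is made for them only; others in the source may bear on it.

Measured compounds:
Compound 1, `O=C(NCc1ccc(S(=O)(=O)c2ccccc2)cc1)N1Cc2cccnc2C1`, gives > 2000 nM in a functional assay on A2780 cells (Homo sapiens) for cytotoxicity, read by sulforhodamine B assay, with a stated time of 72 h; a higher number here means a weaker inhibitor, a lower number a stronger inhibitor.
Compound 2, `O=S(=O)(c1ccccc1)c1ccc(CNS(=O)(=O)N2Cc3ccncc3C2)cc1`, gives > 2000 nM in this assay.
Compound 3, `O=C(NCc1ccc(S(=O)(=O)C2CCCOC2)cc1)N1Cc2ccncc2C1`, gives 32 nM in this assay.

The value of compound 1 in this assay is a limit of the assay, not a number. The same holds for compound 2, whose value is also a limit. Compounds 1 and 2 thus both sit at the limit of > 2000 nM in this assay, at which 2 of the 3 values shown sit. Going by the values given here, compound 3 is the only compound of the three with a measured number, and it stands alone as the sole point of reference among the values shown.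

The step from compound 3 leads to compound 4, `O=C(NCc1ccc(S(=O)(=O)N2CCC(N3CCCC3)CC2)cc1)N1Cc2ccncc2C1`, which is not yet measured. The change is 4-(pyrrolidin-1-yl)piperidin-1-yl in place of oxan-3-yl on a sulfonyl sulfur. Among the compounds with values here, no step between two measured compounds is available to set the size of such an exchange on the sulfonyl sulfur, so the expectation rests on compound 3 alone and carries wide uncertainty. The change from compound 3 to compound 4 is expected to be a loss in potency, a 4.7-fold higher number from compound 3 to compound 4 (0.67 log units; beyond the scatter), somewhat beyond the usual scatter. For compound 4 the estimate in this assay is 150 nM, with a range from 30 nM to 1500 nM.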

Compound 4, half-maximal inhibitory concentration: 5.6 nM
For compound 4 the middle estimate is 27-fold (1.43 log units) above the measured one, and the stated range ends above it.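

Going by these compounds alone, exchanging oxan-3-yl for 4-(pyrrolidin-1-yl)piperidin-1-yl on a sulfonyl sulfur whose other neighbour is an aromatic carbon gives a 5.7-fold lower number from compound 3 to compound 4 (0.76 log units; beyond the scatter) in this assay, the first step at this position that can be read from two numbers. The position therefore accepts a group of 11 heavy atoms with two non-aromatic rings and nitrogen as its hetero atom in place of one of 6 heavy atoms with a single ring and oxygen as its hetero atom, and the number still falls. Nothing measured among the compounds shown accounts for this step.

The exchange alters the ring count, the size and the hetero atoms all at once, so the compounds shown leave open which of these goes with the lower number. A plain piperidin-1-yl, a morpholin-4-yl or an open-chain dimethylamino group on the same sulfur would begin to separate these features, and a carboxylic acid in place of the pyrrolidine ring would show how far the terminal amine can be exchanged.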